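Swapping an Aminopentylamino Chain for Chloro on Two Cores

The source may report more compounds than this note shows. Statements on the series, on what has been measured and on what is new or still open speak of the compounds shown alone.

Three compounds have been measured in an assay on Raji cells for inhibition of Monocarboxylate transporter 1 (Homo sapiens), read by MTT assay, with a stated time of 96 h; on this read-out higher numbers stand for an effect only at larger amounts of compound and lower numbers for an effect already at smaller amounts:
compound 1 `CC(C)Cc1nn(C)c(=O)c2c(SCCCO)n(Cc3cnc(NCCCCCN)c4ccccc34)cc12` gives 0.8 nM;
compound 2 `CC(C)Cc1nn(C)c(=O)c2c(SCCCO)n(Cc3ccnc(NCCCCCN)c3)cc12` gives 520 nM;
compound 3 `CC(C)Cc1nn(C)c(=O)c2c(SCCCO)n(Cc3cnc(Cl)c4ccccc34)cc12` gives 55 nM.

Compound 1 and compound 3 share a core and differ in one place: chloro in place of (5-aminopentyl)amino on an aromatic carbon. That change made the step of a 69-fold higher number from compound 1 to compound 3 (1.84 log units; beyond the scatter), a large loss of effect. Compound 2 carries the same (5-aminopentyl)amino group but on a different core; the difference between the two cores is not broken down here. In this assay compound 2 stands far weaker than compound 1 and also weaker than compound 3.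

Compound 4 `CC(C)Cc1nn(C)c(=O)c2c(SCCCO)n(Cc3ccnc(Cl)c3)cc12` has not yet been measured. It is made from compound 2 by the change (chloro in place of (5-aminopentyl)amino on an aromatic carbon). This is the same kind of change as that from compound 1 to compound 3, but not the same: in compound 1 the group sits on a ring that is part of a fused or bridged system of two rings, ortho to a fused ring, meta to a fused ring and para to a large group, whereas in compound 2 it sits on a single six-membered aromatic ring with 1 nitrogen, meta to a large group. Because the step of a 69-fold higher number from compound 1 to compound 3 (1.84 log units; beyond the scatter) was so large, a step of roughly similar size is expected from compound 2 to compound 4, a 29-fold higher number from compound 2 to compound 4 (1.46 log units; beyond the scatter), though the weaker starting point of compound 2 at 520 nM makes the exact size uncertain. Compound 4 is therefore estimated at 15000 nM, expected between 3000 nM and 80000 nM.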

Compound 4, half-maximal effective concentration: 1000 nM
For compound 4 the middle estimate is 15-fold (1.18 log units) above the measured one; measured number outside the range, below it.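

On the core of compound 2, putting chloro in place of (5-aminopentyl)amino gave a 1.9-fold higher number from compound 2 to compound 4 (0.28 log units; within the scatter), so this assay does not tell these two compounds apart. The large step seen on the core of compound 1 therefore did not carry over to the core of compound 2, and the size of this change depends on the core that carries it: the same change on two cores in this assay, a 69-fold higher number (1.84 log units; beyond the scatter) from compound 1 to compound 3 and a 1.9-fold higher number (0.28 log units; within the scatter) from compound 2 to compound 4, 36-fold (1.55 log units) apart, beyond the scatter of two such steps

Among these compounds, this rests on only two matched pairs, so it shows that a step measured on one core cannot simply be transferred to another, but it gives no general rule for other cores. The two cores also differ in more than one way, and these compounds do not show which difference accounts for the gap between the steps.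

Going by these compounds, it remains open whether a shorter chain such as (3-aminopropyl)amino, or a simple amine, would give a large step on the core of compound 1 and a small one on the core of compound 2. Also open, on these data alone, is how a chain of the same length ending in a hydroxyl group instead of an amine would read on each core.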